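The compounds below may be only part of what the source reports. "The series", "measured", "known", "first", "only" and "open" are said of these compounds alone.

Compound 1, with the structure `CCn1c(SCC(=O)Nc2ccc(C(C)=O)cc2)nnc1-c1ccc(OC)cc1`, is the starting point. Among the compounds with values here, in a functional assay on the whole organism (strain albino) for inhibition, with Rattus norvegicus as the target, read by paw edema, with stated times of 30 min and 1 h, at a dose of 0.28 mmol/kg by the oral route (a higher number here means more inhibition at the dose given (going by the name of the read-out), a lower number less inhibition), compound 1 gives 51%, the higher of the two numbers measured so far. Within the data shown here, its only neighbour is compound 2, with the structure `C=CCn1c(SCC(=O)Nc2ccc(C(C)=O)cc2)nnc1-c1ccc(OC)cc1`, and in this assay compound 2 gives 50%. Among the measured compounds shown here, the one measured step, a number 1 percentage points lower from compound 1 to compound 2 (within the scatter), concerns a vinyl in place of a methyl on a saturated chain carbon bound to an aromatic nitrogen and stays within the usual scatter, so the two compounds cannot be ranked against each other.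

Compound 3, with the structure `CCn1c(SCC(=O)Nc2ccc(C(C)=O)cc2)nnc1-c1ccccc1`, is not yet measured. It differs from compound 1 in one place: hydrogen in place of methoxy on an aromatic carbon. For the measured compounds named here, no measured step touches the methoxy group, so the measured data give no direct guide to this change; the single known step shows only that a small change elsewhere left the inhibition unchanged. The expectation for compound 3 is therefore a step of a number 6 percentage points lower from compound 1 to compound 3 (within the scatter), with the range kept wide to reflect the lack of a bearing step. Compound 3 is estimated at 45%, between 25% and 65%.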

Compound 3, a percentage reported as inhibition, in the whole organism at one dose (the size of the read-out at that dose, not a potency): 50%
Compound 3: middle estimate off by 5 percentage points, on the low side; low and high end bracket the measured number.
By their numbers in this assay, from the lowest: compounds 2, 3 and 1 (each within the scatter of the next).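

Going from 4-methoxyphenyl to phenyl gives a number 1 percentage points lower from compound 1 to compound 3 (within the scatter) in this assay, so at this aromatic carbon, para to a large group, the methoxy group can be replaced by hydrogen with no difference that this read-out can separate. Within the data shown here, the earlier pair spoke only to the chain on the aromatic nitrogen, whereas this step is the first to test a group on the six-membered aromatic ring, and the presence of the methoxy group proves not to be required for the inhibition seen at this one dose. No measurement shown here gives a reason for this result.

Going by these compounds, only methoxy and hydrogen have been compared at this place, so it remains open whether a chlorine atom, a nitro group or a dimethylamino group there would also stay within the scatter of compound 1 or would shift the inhibition. Also open, on these data alone, is how much the acetyl group elsewhere in the molecule contributes, for instance if a carboxylic acid stood in its place, and whether the compounds would still read alike at other doses.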